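A few compounds are considered here, and "the series" means these few. Any claim that something is new, unique, unknown or untested is made for them only; others in the source may bear on it.

Measured so far in a functional assay on RXF 393 cells (Homo sapiens) for inhibition, read by sulforhodamine B assay, with a stated time of 48 h; on this read-out higher numbers stand for weaker inhibition of growth and lower numbers for stronger inhibition of growth:
compound 1 `COc1cc(-c2nn(-c3cccc(NC(=O)Nc4cccc(C(F)(F)F)c4)c3)cc2-c2ccncc2)ccc1Cl`: 1940 nM
compound 2 `O=C(Nc1cccc(-n2cc(-c3ccncc3)c(-c3ccc(Cl)c(O)c3)n2)c1)Nc1cccc(C(F)(F)F)c1`: 12000 nM
compound 3 `O=C(Nc1cccc(-n2cc(-c3ccncc3)c(-c3ccc(Cl)c(O)c3)n2)c1)Nc1ccc(Cl)c(C(F)(F)F)c1`: 1670 nM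

Compound 1 holds the second highest of the three numbers; compound 3 lies within the scatter of it, compound 2 beyond it: a 6.2-fold higher number from compound 1 to compound 2 (0.79 log units; beyond the scatter), then a 7.2-fold lower number from compound 2 to compound 3 (0.86 log units; beyond the scatter). Compound 4 `COc1cc(-c2nn(-c3cccc(NC(=O)Nc4ccc(Cl)c(Cl)c4)c3)cc2-c2ccncc2)ccc1Cl` is not yet measured. It differs from compound 1 as follows: 3,4-dichlorophenyl in place of 3-(trifluoromethyl)phenyl on an amide-type nitrogen. Among the measured compounds shown here, no measured step exchanges the trifluoromethyl group itself; the only step that touches this phenyl, a 7.2-fold lower number from compound 2 to compound 3 (0.86 log units; beyond the scatter), puts chloro in place of hydrogen and lowers the number modestly, so a modest lowering, at most, is expected in this assay, with the exchange of the trifluoromethyl group an open question. Compound 4 is therefore estimated at 1200 nM, between 400 nM and 4000 nM, an expected step of a 1.6-fold lower number from compound 1 to compound 4 (0.21 log units; within the scatter).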

Compound 4, concentration for total growth inhibition: 2440 nM
The estimate for compound 4 lay 2.0-fold (0.31 log units) below the measured number; measured number inside the range.
By their numbers in this assay, from the lowest: compounds 3, 1 and 4 (each within the scatter of the next); then compound 2.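

Among the compounds shown here, on the group carried by the amide-type nitrogen, 3,4-dichlorophenyl in place of 3-(trifluoromethyl)phenyl is the first exchange of the trifluoromethyl group itself, and in this assay it stays within the scatter (a 1.3-fold higher number from compound 1 to compound 4 (0.10 log units; within the scatter)). With the core of compound 1 kept, the two groups cannot be told apart on this read-out. Nothing available bears on why they read alike.

On these data alone, whether the same exchange reads alike on compound 2, with its hydroxy group, remains open. Also open, as far as these compounds go, is how a phenyl carrying an amine or a carboxylic acid would read at this position.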